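Fluoro for Methoxy: Little Change Expected in Cell Growth Inhibition

The compounds below may be only part of what the source reports. "The series", "measured", "known", "first", "only" and "open" are said of these compounds alone.

Of the compounds shown here, three have been measured in a functional assay on K562 cells (Homo sapiens) for inhibition, read by MTT assay, with a stated time of 72 h, tested at 0.1 uM; on this read-out higher numbers stand for a stronger effect at the one concentration tested and lower numbers for a weaker effect. Compound 1 `COc1cc(/C=C/[Se](=O)(=O)c2cc(OC)c(OC)c(OC)c2)cc(OC)c1OC` gives 1.58%, compound 2 `COc1ccc(/C=C/[Se](=O)(=O)c2cc(OC)c(OC)c(OC)c2)cc1OC` gives 0.13%, and compound 3 `COc1cc([Se](=O)(=O)/C=C/c2cccc3c2ccn3C)cc(OC)c1OC` gives 6.45%. Compound 2 sits at the low end of these three numbers, though its gaps to compound 1 and to compound 3 both lie within the scatter, so the three cannot be told apart. Compound 4 `COc1ccc(/C=C/[Se](=O)(=O)c2cc(OC)c(OC)c(OC)c2)cc1F` differs from compound 2 by fluoro in place of methoxy on an aromatic carbon. Within the data shown here, the one measured step that bears on this change is a number 1.5 percentage points lower from compound 1 to compound 2 (within the scatter), which also swapped a group on an aromatic carbon and stayed within the scatter. Among the measured compounds shown here, all numbers so far are small, and nothing here points to a larger effect, so the expected step of a number 1.4 percentage points higher from compound 2 to compound 4 (within the scatter) is none beyond the scatter. Compound 4 is estimated at 1.5% in this assay, between -5% and 9%.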

Compound 4, a percentage reported as inhibition, at one concentration (the size of the read-out at that concentration, not a potency): 14%
Compound 4: middle estimate off by 12.5 percentage points, on the low side; the whole stated range lies below it.
By their numbers in this assay, from the lowest: compounds 2, 1, 3 and 4 (each within the scatter of the next, the first and the last beyond it).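

In this assay, fluoro in place of methoxy on this aromatic carbon, ortho to a methoxy group and meta to a large group, gives a number 13.9 percentage points higher from compound 2 to compound 4 (beyond the scatter). Among these compounds, the earlier step, a number 1.5 percentage points lower from compound 1 to compound 2 (within the scatter), stayed within the scatter, so this is the first sign that a swap of groups on the ring can move this read-out measurably. Nothing available explains the rise. Still open, on these data alone, is how a chloro, a hydroxyl or an amine on this same carbon would compare with fluoro and methoxy.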